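Chloro for Acetyl in a Cytotoxicity Series

A few compounds are considered here, and "the series" means these few. Any claim that something is new, unique, unknown or untested is made for them only; others in the source may bear on it.

Compound 1 `CC(=O)c1ccc(NC(=O)Nc2cc(C)nc3ccccc23)cc1` was tested in an ADME assay on Raji cells (Homo sapiens) for cytotoxicity, with a stated time of 72 h (a higher number here means that more compound is needed for the effect, a lower number that less compound is needed), where compound 1 gives > 25000 nM, which is a limit of the assay rather than a number. Compound 2 `Cc1cc(NC(=O)Nc2ccccc2C(N)=O)c2ccccc2n1` in this assay gives > 25000 nM, again only a limit. Compound 3 `COc1cccc(NC(=O)Nc2cc(C)nc3ccccc23)c1` in this assay gives > 25000 nM, also a limit. Compound 1 thus stands at the limit of > 25000 nM in this assay, at which 3 of the 3 values shown sit, with nothing in these numbers to set it apart from the other two. Compound 4 `Cc1cc(NC(=O)Nc2ccc(Cl)cc2)c2ccccc2n1` has not yet been tested in this assay. It differs from compound 1 in one place: chloro in place of acetyl on an aromatic carbon. For the measured compounds named here, no step between measured compounds has been recorded, so no size of effect can be read from the data. The author expects the step that the limit leaves unreadable from compound 1 to compound 4 to be none beyond the scatter, given that compound 1 sits at the limit of > 25000 nM in this assay, at which 3 of the 3 values shown sit, together with every other measured compound. Compound 4 is therefore expected to give 30000 nM in this assay, with a range from 8000 nM to 100000 nM, most likely reported once more as a limit.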

Compound 4, half-maximal effective concentration: > 25000 nM
Compound 4: no number, only a limit; the forecaster's own chance of this, stated with the estimate: 80%; the middle value is on the limit's open side.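

For the compounds shown here, the result for compound 4 is again only a limit, as is that for compound 1, so no step between compound 1 and compound 4 can be read: the limit of > 25000 nM in this assay, at which 4 of the 4 values shown sit. The compounds shown leave open whether any change to the shared core would yield a measurable value in this assay.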